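The source may report more compounds than this note shows. Statements on the series, on what has been measured and on what is new or still open speak of the compounds shown alone.

Two compounds with measured values set the scene. Compound 1, `N#CC1CN1C(=O)Nc1ccccc1`, is a small urea built from an aniline; in a functional assay on RPMI-8226 cells (Homo sapiens) for cytotoxicity, read by MTT assay (a lower number here means a stronger inhibitor, a higher number a weaker inhibitor), compound 1 gives 5300 nM. Compound 2, `NC(=O)N1CC1C1=NC(C(=O)O)CS1`, carries a primary urea on the same three-membered ring and a carboxylic acid on its other ring. For compound 2 the read-out in this assay is a limit of the test and not a number: compound 2 gives > 500000 nM, which is the limit of > 500000 nM in this assay, at which 1 of the 2 values shown sits. Compound 2 therefore stands at the weak end of everything shown, with no measured inhibition at all. Compound 3, `CNC(=O)N1CC1C1=NC(C(=O)O)CS1`, is the next step: methyl in place of hydrogen on an amide-type nitrogen. Among the measured compounds shown here, no step between measured compounds is available to guide the size of this change. Given that compound 2 sits at a limit, no shift beyond the scatter is expected, and the step of a number no higher from compound 2 to compound 3 (the limit leaves the size open) is expected to be essentially none. Compound 3 is estimated at 500000 nM, within a range of 150000 nM to 500000 nM, most likely again reported only as a limit.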

Compound 3, half-maximal inhibitory concentration: > 500000 nM
Compound 3 gave a limit, no number; the forecaster's own chance of this, stated with the estimate: 80%; the middle value sits exactly at the limit.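

Compound 2 and compound 3 each give only a limit of the test and not a number, so no size can be read for the step between them: the limit of > 500000 nM in this assay, at which 2 of the 3 values shown sit.

As far as these compounds go, whether methyl in place of hydrogen on an amide-type nitrogen changes the activity at all remains open.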